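Swapping the Aryl Group on a Urea Nitrogen

The compounds below may be only part of what the source reports. "The series", "measured", "known", "first", "only" and "open" are said of these compounds alone.

Compound 1 `Cc1ccc(NC(=O)NCCCOc2cccc(CN3CCCCC3)c2)cc1`: in an assay on isolated protein for inhibition of histamine H2 receptor (Cavia porcellus) (a lower number here means tighter binding, a higher number weaker binding), compound 1 gives 631 nM.
Compound 2 `O=C(NCCCOc1cccc(CN2CCCCC2)c1)NCc1ccccc1`: compound 2 gives 347 nM.
Compound 3 `O=C(NCCCOc1cccc(CN2CCCCC2)c1)Nc1cccc(C(F)(F)F)c1`: compound 3 gives 813 nM.

Among these three numbers compound 1 has the second highest. Its nearest neighbour is compound 3 and its furthest compound 2; the steps read a 1.3-fold higher number from compound 1 to compound 3 (0.11 log units; within the scatter) and a 1.8-fold lower number from compound 1 to compound 2 (0.26 log units; within the scatter).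

Compound 4 `O=C(NCCCOc1cccc(CN2CCCCC2)c1)Nc1cccc(Cl)c1` differs from compound 1 in one place: 3-chlorophenyl in place of 4-methylphenyl on an amide-type nitrogen. The step that bears most on this is another swap of one aromatic ring for another on the same nitrogen, a 1.3-fold higher number from compound 1 to compound 3 (0.11 log units; within the scatter). For the measured compounds named here, the only step beyond the scatter, a 2.3-fold higher number from compound 2 to compound 3 (0.37 log units; beyond the scatter), concerns a benzyl rather than an aryl group. A step within the scatter is therefore expected: a 1.1-fold higher number from compound 1 to compound 4 (0.05 log units; within the scatter). For compound 4 the estimate in this assay is 700 nM, between 300 nM and 1600 nM.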

Compound 4, dissociation constant: 316 nM
Estimate against measurement, compound 4: 2.2-fold (0.35 log units) above; low and high end bracket the measured number.
By their numbers in this assay, from the lowest: compounds 4, 2, 1 and 3 (each within the scatter of the next, the first and the last beyond it).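

On this amide-type nitrogen, 3-chlorophenyl cannot be told apart from the other two groups it replaces, with a 2.0-fold lower number from compound 1 to compound 4 (0.30 log units; within the scatter) and a 1.1-fold lower number from compound 2 to compound 4 (0.04 log units; within the scatter). For the compounds shown here, the new finding lies on the aromatic carbon, where chloro in place of trifluoromethyl gives a 2.6-fold lower number from compound 3 to compound 4 (0.41 log units; beyond the scatter), the first step beyond the scatter between two aromatic groups on this nitrogen.

From the compounds shown here alone, what fluoro, methoxy or nitrile would give in place of chloro remains open, as does whether 3-chlorobenzyl would match 3-chlorophenyl. No other measurement here bears on why chloro and trifluoromethyl differ.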